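This account rests on a few compounds, and the source may have more. Where it says the series, first, only, none or still open, it means among the compounds named here.

Among the measured compounds shown here, in a functional assay on MCF7 cells (Homo sapiens) for antiproliferative activity, read by MTT assay (a lower number here means a stronger inhibitor, a higher number a weaker inhibitor), compound 1 (`COc1cc2c(Oc3ccc(NC(=O)Nc4ccccc4)cc3)ccnc2cc1OCCCCCCC(=O)NO`) gives 1040 nM and compound 2 (`COc1cc2c(Oc3ccc(NC(=O)Nc4ccccc4F)cc3)ccnc2cc1OCCCCCCC(=O)NO`) gives 660 nM, so compound 2 stands within the scatter of the only other measured value. Compound 3 (`COc1cc2c(Oc3ccc(NC(=O)Nc4ccc(Cl)c(C(F)(F)F)c4)cc3)ccnc2cc1OCCCCCCC(=O)NO`) has 4-chloro-3-(trifluoromethyl)phenyl in place of 2-fluorophenyl on an amide-type nitrogen. For the measured compounds named here, the only measured step bearing on this change is a 1.6-fold lower number from compound 1 to compound 2 (0.20 log units; within the scatter), which lies within the scatter and involves a single fluoro in place of hydrogen. It therefore gives no firm direction, and no change beyond the scatter is expected, the estimate being a 1.1-fold lower number from compound 2 to compound 3 (0.04 log units; within the scatter). For compound 3 the estimated value is 600 nM, with an expected range of 200 nM to 1800 nM.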

Compound 3, half-maximal inhibitory concentration: 5150 nM
Compound 3: middle estimate off by 8.6-fold (0.93 log units), on the low side, outside the stated range (above it).
By their numbers in this assay, from the lowest: compounds 2 and 1 (each within the scatter of the next); then compound 3.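

In this assay, the group on the amide-type nitrogen now shows that it can shift the number beyond the scatter: 4-chloro-3-(trifluoromethyl)phenyl gives a 7.8-fold higher number from compound 2 to compound 3 (0.89 log units; beyond the scatter), and, set against plain phenyl, a 5.0-fold higher number from compound 1 to compound 3 (0.69 log units; beyond the scatter). The earlier single fluoro step gave no such firm direction, whereas this larger change points towards a weaker inhibitor. Nothing available explains this shift.

Whether the chloro or the trifluoromethyl alone accounts for the shift remains open. So does how a phenyl ring carrying a methoxy group or an amine would read at this nitrogen.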